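This account rests on a few compounds, and the source may have more. Where it says the series, first, only, none or still open, it means among the compounds named here.

Compound 1 `CCCn1c(=O)c2nc([C@@H]3CC4CCC3C4)[nH]c2n(CCC)c1=O`: 3.8 nM
Compound 2 `CCCC(CCC)Nc1ncnc2c1ncn2C1O[C@H](CO)[C@@H](O)[C@H]1O`: 3.3 nM

In an assay on cell membranes for binding affinity to adenosine receptor A1 (Cavia porcellus), read by radioligand binding (a higher number here means a weaker inhibitor, a lower number a stronger inhibitor), compound 1 gives 3.8 nM, the higher of the two numbers, while compound 2 gives 3.3 nM; the two values lie within the scatter of each other, so neither can be called the stronger binder. Compound 3 `CCCn1c(=O)c2nc(CC3CC3)[nH]c2n(CCC)c1=O` differs from compound 1 in one place: a group of 4 heavy atoms (4 carbon; one three-membered non-aromatic ring of carbon only) in place of a group of 7 heavy atoms (7 carbon; 2 five-membered non-aromatic rings of carbon only), on an aromatic carbon. For the measured compounds named here, no measured pair shows a change of this kind, so its size must be estimated. The expected step in this assay is a 7.9-fold higher number from compound 1 to compound 3 (0.90 log units; beyond the scatter), a loss beyond the scatter. The estimate for compound 3 in this assay is 30 nM, with a range from 8 nM to 120 nM.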

Compound 3, inhibition constant: 120 nM
Estimate against measurement, compound 3: 4.0-fold (0.60 log units) below; low and high end bracket the measured number.
By their numbers in this assay, from the lowest: compounds 2 and 1 (each within the scatter of the next); then compound 3.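

At this place on the shared core, between two ring nitrogen atoms, the choice of carbon group clearly matters: replacing the group with 2 five-membered non-aromatic rings by cyclopropylmethyl gives in this assay a 32-fold higher number from compound 1 to compound 3 (1.50 log units; beyond the scatter). Both groups have no hydrogen-bond donors or acceptors, so this loss appears without any change in those counts. Nothing available explains the loss.

From the compounds shown here alone, whether a single cyclopentyl ring or a longer chain such as butyl would stay near compound 1 remains open. So does the effect of reversing the defined stereocentre of compound 1.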